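The source may hold more compounds than are shown below. What is called first, only, known or untested is meant among the compounds shown, and "the series" means these compounds.

Measured in a functional assay on L1210/0 cells (Mus musculus) for antiproliferative activity, read by MTT assay, with a stated time of 72 h; a higher number here means a weaker inhibitor, a lower number a stronger inhibitor:
- compound 1 `O=C1O/C(=C\Cn2cnc3ccn(C/C=C4\OC(=O)C(OCc5ccccc5)=C4OCc4ccccc4)c3c2=O)C(OCc2ccccc2)=C1OCc1ccccc1` gives 4500 nM
- compound 2 `O=C1O/C(=C\Cn2cnc3cc[nH]c3c2=O)C(OCc2ccccc2)=C1OCc1ccccc1` gives 28000 nM
- compound 3 `O=C1NC(O)(CCn2cnc3ccnc(Cl)c32)C(OCc2ccccc2)=C1OCc1ccccc1` gives "not determined" (no result reported)

Of the two numbers available, compound 2 at 28000 nM holds the higher, and so the weaker inhibition. Compound 1 at 4500 nM lies lower by more than the usual scatter. Compound 3 offers no comparison.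

The next entry is compound 4 `O=C1O/C(=C\Cn2cnc3ncc(Br)c-3c2)C(OCc2ccccc2)=C1OCc1ccccc1`, still unmeasured. The change from compound 2 is a group of 10 heavy atoms (6 carbon, 3 nitrogen, 1 bromine; one five-membered aromatic ring with 1 hetero atom, one six-membered aromatic ring with 2 hetero atoms) in place of a group of 10 heavy atoms (6 carbon, 3 nitrogen, 1 oxygen; one five-membered aromatic ring with 1 hetero atom, one six-membered aromatic ring with 2 hetero atoms), on a saturated chain carbon bound to a double-bonded chain carbon. The benzyl-bearing part is unchanged, and the exchange takes place on a saturated chain carbon bound to a double-bonded chain carbon.

Within the data shown here, no measured pair isolates this exchange, so the expectation rests on thin ground. The only anchors are the two numbers above. The expected step is a 2.8-fold lower number from compound 2 to compound 4 (0.45 log units; beyond the scatter), a moderate move toward a lower number in this assay, with no change beyond the scatter still possible. For compound 4 the estimated value is 10000 nM, with an expected range from 2500 nM to 40000 nM.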

Compound 4, half-maximal inhibitory concentration: 15000 nM
Compound 4: the middle estimate sits 1.5-fold (0.18 log units) below what was measured; the range from low to high includes it.
By their numbers in this assay, from the lowest: compound 1; then compounds 4 and 2 (each within the scatter of the next).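

In this assay, among these compounds, the exchange on a saturated chain carbon bound to a double-bonded chain carbon gives a 1.9-fold lower number from compound 2 to compound 4 (0.27 log units; within the scatter), the first step at this place. The entering group carries bromine where the leaving group carries oxygen, with 0 hydrogen-bond donors against 1 and without the double bond outside aromatic rings, yet these differences taken together leave the number within the scatter. No supporting measurement accompanies this step, and nothing shown accounts for the result.

Still open, on these data alone, is how an amine or a methyl group in place of the bromine would read in this assay. The bromine and the loss of the hydrogen-bond donor arrive together in compound 4, and the compounds shown do not separate them.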